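This account rests on a few compounds, and the source may have more. Where it says the series, first, only, none or still open, it means among the compounds named here.

Compound 1, `O=C1Nc2ccc([N+](=O)[O-])cc2/C1=C/c1ccco1`, in an ADME assay on A549 cells (Homo sapiens) for cytotoxicity, read by MTT assay, with a stated time of 72 h (on this read-out higher numbers stand for weaker inhibition and lower numbers for stronger inhibition), gives 329000 nM.
Compound 2, `O=C1Nc2ccc(Br)cc2C1=Cc1cccnc1`, in this assay gives 31400 nM.

Going by the values given here, compound 2 stands at the lowest of the two numbers; compound 1, its only neighbour, lies higher by a gap that is beyond the scatter. Compound 3, `O=C1Nc2ccc(Br)cc2C1=Cc1ccncc1`, is not yet measured. It differs from compound 2 in one place: pyridin-4-yl in place of pyridin-3-yl on a double-bonded chain carbon bound to a double-bonded ring carbon. Among the compounds with values here, no step between two measured compounds exists to guide the size of this change, so for the step from compound 2 to compound 3 in this assay no shift beyond the scatter is expected in either direction, a 1.0-fold lower number from compound 2 to compound 3 (0.02 log units; within the scatter). Compound 3 is therefore estimated at 30000 nM, within 10000 nM to 90000 nM.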

Compound 3, half-maximal inhibitory concentration: 22300 nM
Compound 3: the middle estimate sits 1.3-fold (0.13 log units) above what was measured, and the stated range covers the measured number.
By their numbers in this assay, from the lowest: compounds 3 and 2 (each within the scatter of the next); then compound 1.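

At this place, on a double-bonded chain carbon bound to a double-bonded ring carbon, pyridin-4-yl in place of pyridin-3-yl gives a 1.4-fold lower number from compound 2 to compound 3 (0.15 log units; within the scatter) in this assay. Going by these compounds alone, this is the first step read at this position, and it shows that the read-out does not separate these two groups, which have the same atoms joined differently. No measured evidence bears on this result. The compounds shown leave open whether a phenyl, a morpholine or a carboxylic acid at this place would shift the number beyond the scatter. They also leave open whether another group in place of the bromine would do so.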